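A Methoxy Step Retraced on a Different Core

The compounds below may be only part of what the source reports. "The series", "measured", "known", "first", "only" and "open" are said of these compounds alone.

Compound 1 `O=C(Nc1ccc(Cl)cc1F)c1ccccc1OCc1ccc(F)cc1F` was tested in an ADME assay on RAW264.7 cells (Mus musculus) for cytotoxicity, read by MTT assay, with a stated time of 24 h; on this read-out higher numbers stand for lower toxicity in this test and lower numbers for higher toxicity in this test. In this assay compound 1 gives only a limit, > 40000 nM. Compound 2 `COc1ccc(C(=O)Nc2ccc(Cl)cc2F)c(OCc2ccc(F)cc2F)c1` differs from it by methoxy in place of hydrogen on an aromatic carbon. In this assay compound 2 also gives a limit, > 40000 nM. The step that the two limits leave unreadable from compound 1 to compound 2 cannot be sized because of the limit of > 40000 nM in this assay, at which 2 of the 3 values shown sit. Compound 3 `O=C(Nc1ccc(I)cc1F)c1ccccc1O` has another core; the difference between the two cores is not broken down here. In this assay, among the compounds with values here, compound 3 gives 23300 nM, the only number among the three values. Compound 4 `COc1ccc(C(=O)Nc2ccc(I)cc2F)c(O)c1` differs from compound 3 by methoxy in place of hydrogen on an aromatic carbon, the same kind of change as before, though here the entering group sits meta to a hydroxy group rather than meta to a large group. For compound 4 the expected step is a 1.1-fold higher number from compound 3 to compound 4 (0.03 log units; within the scatter), judged small. This rests on compound 3 alone, whose value is 23300 nM. Compound 4 is estimated at 25000 nM, between 10000 nM and 40000 nM.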

Compound 4, half-maximal cytotoxic concentration: 27600 nM
The estimate for compound 4 lay 1.1-fold (0.04 log units) below the measured number; the measured number falls inside the stated range.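

On the second core, methoxy in place of hydrogen on an aromatic carbon gives, in this assay, a 1.2-fold higher number from compound 3 to compound 4 (0.07 log units; within the scatter). The change therefore leaves the number within the usual scatter on this core, for this single pair. It does not show that the change behaves alike on both cores, since the matching step on the first core cannot be read, and so no comparison between the two steps can be made: the limit of > 40000 nM in this assay, at which 2 of the 4 values shown sit.

The compounds shown leave open whether an amine or a carboxylic acid in place of that same hydrogen would also stay within the scatter in this assay. They also leave open whether methoxy would do so on any further core.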